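A few compounds are considered here, and "the series" means these few. Any claim that something is new, unique, unknown or untested is made for them only; others in the source may bear on it.

Measured so far: compound 1 `COc1ccc2c(c1)CCc1c-2c2c(c3c4ccccc4n(CCCO)c13)CNC2=O`, 87 nM in an assay on isolated protein for inhibition of mitogen-activated protein kinase kinase kinase 11 (Homo sapiens); on this read-out lower numbers stand for stronger inhibition and higher numbers for weaker inhibition; compound 2 `COc1ccc2c(c1)CCc1c-2c2c(c3c1[nH]c1ccccc13)CNC2=O`, 274 nM.

Compound 2 holds the higher of the two numbers; the step between them is a 3.1-fold higher number from compound 1 to compound 2 (0.50 log units; beyond the scatter), a change of hydrogen in place of 3-hydroxypropyl on an aromatic nitrogen. Compound 3 `CC(C)Oc1ccc2c(c1)CCc1c-2c2c(c3c1[nH]c1ccccc13)CNC2=O` differs from compound 2 by isopropyl in place of methyl on an oxygen on an aromatic ring. For the measured compounds named here, no measured step touches this oxygen; the single step known concerns a different place, so nothing bears directly on it. A step of a 1.1-fold higher number from compound 2 to compound 3 (0.04 log units; within the scatter) is therefore expected, none beyond the scatter. Compound 3 is estimated at 300 nM, between 120 nM and 750 nM.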

Compound 3, half-maximal inhibitory concentration: 159 nM
Beside the measured number, compound 3's estimate is 1.9-fold (0.28 log units) above it; the measured number falls inside the stated range.
By their numbers in this assay, from the lowest: compounds 1, 3 and 2 (each within the scatter of the next, the first and the last beyond it).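

In this assay, for the compounds shown here, methoxy to isopropoxy on an aromatic ring gives a 1.7-fold lower number from compound 2 to compound 3 (0.24 log units; within the scatter) and is the first reading at this oxygen. Isopropyl in place of methyl therefore leaves the number within the scatter, with hydrogen on the aromatic nitrogen in both compounds. No supporting measurement accounts for this result.

From the compounds shown here alone, whether the same reading holds with 3-hydroxypropyl on the aromatic nitrogen remains open. Also open, going by these compounds, is how this oxygen would respond to a longer chain ending in an amine or a carboxylic acid.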